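Adding a Chlorine to Compound 2: What to Expect

The source may hold more compounds than are shown below. What is called first, only, known or untested is meant among the compounds shown, and "the series" means these compounds.

Of the compounds shown here, two have so far been tested in a functional assay on cells (Leukemia cell, Homo sapiens) for cytotoxicity, with a stated time of 48 h; a higher number here means a weaker inhibitor of growth, a lower number a stronger inhibitor of growth. Compound 1, `COc1cc2c(/C=C3/C(=O)Nc4ccc(Cl)cc43)c(Cl)n(Cc3cc(OC)c(OC)c(OC)c3)c2cc1C`, gives 1860 nM in this assay. Compound 2, `COc1c(/C=C2/C(=O)Nc3ccccc32)c2ccccc2n1-c1ccccc1`, gives 520 nM. Of the two numbers, compound 2 has the lower one and is thus the stronger inhibitor of growth of the pair; the gap to compound 1 is wider than the scatter of repeated measurements. The two structures differ in many places at once, so no single change can be tied to that gap.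

Compound 3, `COc1c(/C=C2/C(=O)Nc3ccc(Cl)cc32)c2ccccc2n1-c1ccccc1`, has not been measured yet. It differs from compound 2 in one place: chloro in place of hydrogen on an aromatic carbon. Compound 1 also carries a chloro group, yet compound 1 and compound 2 differ elsewhere as well, and the two values give no direct guide to what this one change does.

Among the compounds with values here, with no matching pair of measured compounds to learn from, the step from compound 2 to compound 3 is hard to call. The expectation is a step of only modest size, a 1.3-fold lower number from compound 2 to compound 3 (0.11 log units; within the scatter), leaning slightly toward a lower number, while none beyond the scatter remains quite possible. Compound 3 is expected to give about 400 nM in this assay, with a likely range from 150 nM to 1200 nM.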

Compound 3, concentration for 50% growth inhibition: 2340 nM
Compound 3: middle estimate off by 5.9-fold (0.77 log units), on the low side; measured number above the stated range.
By their numbers in this assay, from the lowest: compound 2; then compounds 1 and 3 (each within the scatter of the next).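

In this assay, within the data shown here, chloro in place of hydrogen on an aromatic carbon of a six-membered aromatic ring of carbon only, part of a fused or bridged system of two rings, gives a 4.5-fold higher number from compound 2 to compound 3 (0.65 log units; beyond the scatter), the first step here that can be tied to a single change. One added chlorine atom, with no ring and no net charge, is thus enough to make the compound a clearly weaker inhibitor of growth, so what sits at this position matters for this read-out. Nothing measured here accounts for this loss of strength.

The compounds shown carry only hydrogen or chloro at this position, so it remains open whether a fluoro group, a methyl group or an amine would bring a similar loss, a smaller one or a gain. On these data alone, it is also open whether chloro would cost as much on another carbon of the same ring, or at this position on a compound with different groups elsewhere.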